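Trimming a Methyl from the Thioether of Compound 1

This account rests on a few compounds, and the source may have more. Where it says the series, first, only, none or still open, it means among the compounds named here.

Among the compounds with values here, compound 1 `Cn1ncc2c(=O)n(-c3ccccc3)c(SC(C)(C)c3ccccc3)nc21` is one of two compounds so far measured in an assay on isolated protein for inhibition of retinal dehydrogenase 2 (Homo sapiens); on this read-out higher numbers stand for weaker inhibition and lower numbers for stronger inhibition. In this assay compound 1 gives 2200 nM, the highest of the two numbers. The other measured compound, compound 2 `Cn1ncc2c(=O)n(-c3ccccc3)c(/C=C/c3cccc(F)c3)nc21`, gives 440 nM in this assay, a lower number that lies beyond the scatter of the two values. Within the data shown here, no pair of measured compounds differs in a single place, so no measured step exists against which the change leading to compound 3 can be gauged.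

Compound 3 `C[C@H](Sc1nc2c(cnn2C)c(=O)n1-c1ccccc1)c1ccccc1` has not yet been measured in this assay. It differs from compound 1 in one place: 1-phenylethyl in place of 1-methyl-1-phenylethyl on a sulfur. The group that leaves and the group that enters each carry one six-membered aromatic ring of carbon only, with no hydrogen-bond donors or acceptors and no net charge, and the entering group has one defined stereocentre. Among the measured compounds shown here, with no measured step of this kind, the expected step, a 1.5-fold lower number from compound 1 to compound 3 (0.17 log units; within the scatter), is small and unlikely to go beyond the scatter, leaning slightly toward a lower number. Compound 3 is therefore estimated to give 1500 nM in this assay, within a range from 600 nM to 4000 nM.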

Compound 3, half-maximal inhibitory concentration: 1480 nM
The estimate for compound 3 lay 1.0-fold (0.01 log units) above the measured number; the measured number falls inside the stated range.
By their numbers in this assay, from the lowest: compound 2; then compounds 3 and 1 (each within the scatter of the next).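

Within the data shown here, the first single-place step in this assay is a 1.5-fold lower number from compound 1 to compound 3 (0.17 log units; within the scatter), with 1-phenylethyl in place of 1-methyl-1-phenylethyl on a sulfur. It shows that, on the core of compound 1, this sulfur can carry a group with one methyl fewer and a defined stereocentre without a change that can be told from the scatter, so the two compounds read as equal here, and the trimming by itself does not move the number in a way this read-out can resolve. No accompanying measurement bears on why the step is this small.

The compounds shown leave open whether the mirror-image form of the 1-phenylethyl group would read like compound 3, since only one form of that stereocentre appears here, and whether a plain benzyl group or a longer chain such as 2-phenylethyl on the same sulfur would stay within the scatter as well. They also leave open how far this place stays as flat once the aromatic ring of the group carries something else, such as a fluorine, an amine or a carboxylic acid.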